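From methyl to fluoro on compound 1

The source may report more compounds than this note shows. Statements on the series, on what has been measured and on what is new or still open speak of the compounds shown alone.

Among the compounds with values here, in a functional assay on HeLa cells (Homo sapiens) for inhibition (on this read-out lower numbers stand for stronger inhibition and higher numbers for weaker inhibition), compound 1 (`Cc1cn(/C=C/C=O)c(=O)[nH]c1=O`) gives 1 uM as the lowest number of the three measured so far. Compound 3 (`Cc1cn(C)c(=O)n(/C=C/C=O)c1=O`) gives 3 uM and compound 2 (`Nc1ccn(/C=C/C=O)c(=O)n1`) gives 15 uM in the same test, and both numbers lie higher than that of compound 1 by more than the usual scatter. Compound 4 (`O=C/C=C/n1cc(F)c(=O)[nH]c1=O`) is still unmeasured. It keeps the 2-formylethenyl group and differs from compound 1 at one place (fluoro in place of methyl on an aromatic carbon), with fluoro in place of methyl on an aromatic carbon. Within the data shown here, no measured pair isolates this place, so the data offer no direct guide. The estimated no change at the digits printed from compound 1 to compound 4 (within the scatter) in this assay stays within the usual scatter, with no clear direction. Compound 4 is therefore estimated at 1 uM with 0.3 uM to 4 uM as the expected range.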

Compound 4, concentration for 50% inhibition: 3 uM
The estimate for compound 4 lay 3.0-fold (0.48 log units) below the measured number; the range from low to high includes it.
By their numbers in this assay, from the lowest: compound 1; then compounds 3 and 4 (each within the scatter of the next); then compound 2.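

In this assay, within the data shown here, the change a 3.0-fold higher number from compound 1 to compound 4 (0.48 log units; beyond the scatter) gives the first direct reading at this position, a modest step beyond the scatter. It shows that methyl and fluoro are not interchangeable here, even though one heavy atom simply replaces another and the rest of compound 1 stays the same. Nothing measured here explains the step. Still open, as far as these compounds go, is how other groups at this aromatic carbon, such as chloro, ethyl or an amine, would compare with methyl. Also open, from the compounds shown here alone, is whether fluoro in place of methyl would give a similar step on compound 3.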